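A few compounds are considered here, and "the series" means these few. Any claim that something is new, unique, unknown or untested is made for them only; others in the source may bear on it.

Compound 1 `CN(C)C(=O)c1cc2cnc(Nc3ccc(NC(=O)C4(C(=O)Nc5ccc(F)cc5)CC4)cc3)nc2n1C1CCCC1` stands at the top of the three measured numbers in a functional assay on A549 cells (Homo sapiens) for inhibition, read by CCK-8 assay, with a stated time of 72 h, tested at 1 uM; a lower number here means less inhibition of growth, a higher number more inhibition of growth at the concentration tested: compound 1 gives 86.6%. Compound 2 `CN(C)C(=O)c1cc2cnc(Nc3ccc(NC(=O)C4(C(=O)Nc5cccc(C#N)c5)CC4)cc3)nc2n1C1CCCC1` gives 70.8% in this assay, and compound 3 `CN(C)C(=O)c1cc2cnc(Nc3ccc(NC(=O)C4(C(=O)Nc5cccc(C(F)(F)F)c5)CC4)cc3)nc2n1C1CCCC1` gives 15.7%. Both measured steps away from compound 1 run downward. The first is a number 15.8 percentage points lower from compound 1 to compound 2 (beyond the scatter), the second a number 70.9 percentage points lower from compound 1 to compound 3 (beyond the scatter). Between the two variants themselves the step is a number 55.1 percentage points lower from compound 2 to compound 3 (beyond the scatter), so the nitrile sits far closer to compound 1 than the trifluoromethyl does.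

Compound 4 `CN(C)C(=O)c1cc2cnc(Nc3ccc(NC(=O)C4(C(=O)Nc5ccc(C#N)cc5)CC4)cc3)nc2n1C1CCCC1` differs from compound 1 by cyano in place of fluoro on an aromatic carbon. Going by the values given here, the step that bears most on this change is the one from compound 1 to compound 2, where a nitrile also replaces the fluorine, though on a different carbon of the same ring; that step was modest. The step from compound 2 to compound 3 concerns a trifluoromethyl and does not apply here. Compound 4 is therefore expected to fall somewhat short of compound 1, a step of a number 10.6 percentage points lower from compound 1 to compound 4 (beyond the scatter) in this assay, and its growth inhibition is estimated at 76%, with a range from 58% to 90%.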

Compound 4, percent growth inhibition at one concentration: 86.1%
For compound 4 the middle estimate is 10.1 percentage points below the measured one; the measured number falls inside the stated range.
By their numbers in this assay, from the lowest: compound 3; then compound 2; then compounds 4 and 1 (each within the scatter of the next).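

In this assay, the step of a number 0.5 percentage points lower from compound 1 to compound 4 (within the scatter) shows that, on this aromatic carbon para to a large group, cyano and fluoro cannot be told apart, so the larger group with its added hydrogen-bond acceptor brings no measurable change here. Going by these compounds alone, the step of a number 15.3 percentage points higher from compound 2 to compound 4 (beyond the scatter) separates what the earlier compounds had left joined: the step from compound 1 to compound 2 changed both the group and its place on the ring, whereas here only the place of the nitrile changes, and the number still moves beyond the scatter, so the nitrile itself does not go with the lower number of compound 2. The step of a number 70.4 percentage points higher from compound 3 to compound 4 (beyond the scatter) is large but changes both group and place at once, and no measurement given here explains any of these steps.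

Whether the low number of compound 3 belongs to the trifluoromethyl or to its place on the ring stays open, since no compound shown carries a trifluoromethyl on the carbon that holds the fluoro in compound 1. As far as these compounds go, how far this carbon tolerates other groups also stays open, for example an amine or a carboxylic acid.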